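The compounds below may be only part of what the source reports. "The series", "measured", "known", "first", "only" and "open" are said of these compounds alone.

Of the compounds shown here, two have so far been measured in a functional assay for agonist activity at G protein-coupled receptor 88 (Homo sapiens), read by HTRF and cAMP accumulation; on this read-out lower numbers stand for an effect already at smaller amounts and higher numbers for an effect only at larger amounts of compound. Compound 1 `CCC(CC)C(N)CCN(C(=O)[C@@H]1C[C@H]1c1ccccc1)c1ccc(-c2ccccc2)cc1` gives 2 nM. Compound 2 `CC(C)C[C@H](N)CN(C(=O)[C@@H]1C[C@H]1c1ccccc1)c1ccc(-c2cccs2)cc1` gives 1500 nM, the highest of the two numbers; since compound 1 and compound 2 differ in more than one place, the two values are only set side by side. Compound 3 `COc1ccc(-c2ccc(N(C[C@@H](N)CC(C)C)C(=O)[C@@H]3C[C@H]3c3ccccc3)cc2)cc1` carries 4-methoxyphenyl in place of thiophen-2-yl on an aromatic carbon. The step expected here is a 5.0-fold lower number from compound 2 to compound 3 (0.70 log units; beyond the scatter), a move toward a lower number that should go beyond the usual scatter. For compound 3 the estimate in this assay is 300 nM, within a range from 40 nM to 3000 nM.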

Compound 3, half-maximal effective concentration: 330 nM
For compound 3 the middle estimate is 1.1-fold (0.04 log units) below the measured one; measured number inside the range.
By their numbers in this assay, from the lowest: compound 1; then compound 3; then compound 2.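

Setting 4-methoxyphenyl in place of thiophen-2-yl on this aromatic carbon, para to a large group, gives a 4.5-fold lower number from compound 2 to compound 3 (0.66 log units; beyond the scatter) in this assay, the first single change that can be read in the series. The position thus responds to the group it carries, even though both groups have the same count of hydrogen-bond donors and acceptors. Nothing available here bears on what lies behind this step. Still open, going by these compounds, is whether the methoxy group or the six-membered ring carries the step; a plain phenyl or a 4-chlorophenyl here would separate the two.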